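Swapping the benzyl ring on a nucleoside scaffold

A few compounds are considered here, and "the series" means these few. Any claim that something is new, unique, unknown or untested is made for them only; others in the source may bear on it.

Compounds measured so far:
- compound 1, `OC[C@H]1O[C@@H](n2cnc3c(NCc4ccc(Br)cc4)ncnc32)[C@H](O)[C@@H]1O`: > 166000 nM
- compound 2, `COc1ccc(CNc2ncnc3c2ncn3[C@@H]2O[C@H](CO)[C@@H](O)[C@H]2O)c(OC)c1`: "not determined" (no result reported)
- compound 3, `COc1cc(CNc2ncnc3c2ncn3[C@@H]2O[C@H](CO)[C@@H](O)[C@H]2O)cc(OC)c1`: "not determined" (no result reported)

All three share the same sugar-bearing core and differ only in the aromatic group attached through a saturated chain carbon to the nitrogen on the aromatic ring. In a functional assay on G-361 cells (Homo sapiens) for antiproliferative activity, with a stated time of 72 h (on this read-out higher numbers stand for weaker inhibition and lower numbers for stronger inhibition), compound 1 reaches only a limit of the assay, > 166000 nM, not a number. For compound 2 and compound 3 this assay reports no value at all, so compound 3 stands nowhere on the numbers shown: the only measured entry in the whole set is the limit (the limit of > 166000 nM in this assay, at which 1 of the 3 values shown sits).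

Compound 4, `Cc1cccc(CNc2ncnc3c2ncn3[C@@H]2O[C@H](CO)[C@@H](O)[C@H]2O)c1O`, arises from compound 3 through (2-hydroxy-3-methylphenyl in place of 3,5-dimethoxyphenyl on a saturated chain carbon bound to a nitrogen on an aromatic ring). Within the data shown here, no step between measured compounds exists to set a scale, and with a single limit as the only anchor, the size of the step from compound 3 to compound 4 in this assay cannot be stated; the sparse evidence points to weak inhibition, probably again at a limit. Compound 4 is therefore expected to give about 100000 nM in this assay, within a range of 20000 nM to 300000 nM.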

Compound 4, half-maximal inhibitory concentration: > 166000 nM
Compound 4: no number, only a limit (the forecaster's own chance of this, stated with the estimate: 60%); middle value at least 1.6-fold (0.22 log units) away from the limit.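

Among these compounds, compound 1 and compound 4 both stand at the same limit, which is not a number, so no step between them can be read. The compounds shown leave open whether any aromatic group on the shared core can give a measurable value in this assay.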